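The source may report more compounds than this note shows. Statements on the series, on what has been measured and on what is new or still open speak of the compounds shown alone.

Measured so far in a functional assay on A549 cells (Homo sapiens) for antiproliferative activity, read by MTT assay, with a stated time of 48 h; on this read-out higher numbers stand for weaker inhibition and lower numbers for stronger inhibition:
compound 1 `COc1ccc(C(=O)/C=C/c2cccc(Cl)c2Oc2c([N+](=O)[O-])cc(C(F)(F)F)cc2[N+](=O)[O-])cc1`: 11.5 ug/mL
compound 2 `O=C(/C=C/c1cccc(Cl)c1Oc1c([N+](=O)[O-])cc(C(F)(F)F)cc1[N+](=O)[O-])c1ccc(Cl)cc1`: 11.7 ug/mL

Compound 2, at 11.7 ug/mL, stands level with compound 1, at 11.5 ug/mL. The two lie within the scatter of each other. Compound 3 `O=C(/C=C/c1cccc(Cl)c1Oc1c([N+](=O)[O-])cc(C(F)(F)F)cc1[N+](=O)[O-])c1ccc(Br)cc1` keeps the shared core of compound 2 and alters one group: bromo in place of chloro on an aromatic carbon. In other words, 4-chlorophenyl becomes 4-bromophenyl. Within the data shown here, only one measured step bears on this change, and it concerns a swap on the same aromatic carbon: a 1.0-fold higher number from compound 1 to compound 2 (0.01 log units; within the scatter). That step stayed within the scatter, although a single pair is thin evidence. No step beyond the scatter is therefore expected in this assay, in either direction. The estimated step is a 1.1-fold lower number from compound 2 to compound 3 (0.03 log units; within the scatter). Compound 3 is expected at 11 ug/mL, with an estimated range of 6 ug/mL to 21 ug/mL.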

Compound 3, half-maximal inhibitory concentration: 10.9 ug/mL
For compound 3 the middle estimate is 1.0-fold (0.00 log units) above the measured one; the measured number falls inside the stated range.
By their numbers in this assay, from the lowest: compounds 3, 1 and 2 (each within the scatter of the next).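

In this assay, the change from 4-chlorophenyl to 4-bromophenyl gives a 1.1-fold lower number from compound 2 to compound 3 (0.03 log units; within the scatter) and bromo in place of methoxy gives a 1.1-fold lower number from compound 1 to compound 3 (0.02 log units; within the scatter), so a second halogen at this position adds no separation. Methoxy, chloro and bromo on this aromatic carbon, para to a large group, now all lie within the scatter of one another, a pattern that holds for compounds 1, 2 and 3 with none going against it. Nothing measured here offers an explanation for this result.

These three groups leave open whether an amine, a carboxylic acid or a longer chain on the same carbon would move the number beyond the scatter. Also open is whether the same holds with the rest of the shared core changed, since every compound shown carries it unaltered.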